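Working notes: the step from compound 3 to compound 4

The source may hold more compounds than are shown below. What is called first, only, known or untested is meant among the compounds shown, and "the series" means these compounds.

Values in a functional assay on VCaP cells (Homo sapiens) for antiproliferative activity, read by propidium iodide staining, with a stated time of 96 h (on this read-out lower numbers stand for stronger inhibition and higher numbers for weaker inhibition), are as follows.
- compound 1 `CC(O)(CSc1ccc(F)cc1)C(=O)Nc1cccc(S(F)(F)(F)(F)F)c1` gives 21900 nM
- compound 2 `CC(O)(CSc1cccc(C(F)(F)F)c1)C(=O)Nc1cccc(S(F)(F)(F)(F)F)c1` gives 20200 nM
- compound 3 `CC(O)(CSc1ccccc1C(F)(F)F)C(=O)Nc1cccc(S(F)(F)(F)(F)F)c1` gives 21000 nM

Compound 3 stands level with the other two compounds, and no order among the three can be read from these numbers. The next compound is compound 4 `CC(O)(CSc1ccccc1OC(F)(F)F)C(=O)Nc1cccc(S(F)(F)(F)(F)F)c1`, which differs from compound 3 in one group: trifluoromethoxy in place of trifluoromethyl on an aromatic carbon. In words, this is trifluoromethoxy in place of trifluoromethyl on an aromatic carbon, ortho to a large group.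

Among the measured compounds shown here, three measured steps bear on this change, all of them swaps in the aryl group on sulfur. They are a 1.1-fold lower number from compound 1 to compound 2 (0.04 log units; within the scatter), a 1.0-fold lower number from compound 1 to compound 3 (0.02 log units; within the scatter) and a 1.0-fold higher number from compound 2 to compound 3 (0.02 log units; within the scatter). Each lies within the scatter. None of them tests trifluoromethoxy, and three compounds make a thin basis.

Going by a 1.0-fold higher number from compound 2 to compound 3 (0.02 log units; within the scatter) and a 1.0-fold lower number from compound 1 to compound 3 (0.02 log units; within the scatter), no step beyond the scatter is expected in this assay, and no direction is favoured. The estimate means a 1.1-fold lower number from compound 3 to compound 4 (0.02 log units; within the scatter) as the expected step. For compound 4 the estimated value is 20000 nM, with an expected range from 12000 nM to 33000 nM.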

Compound 4, half-maximal inhibitory concentration: 12600 nM
For compound 4 the middle estimate is 1.6-fold (0.20 log units) above the measured one; low and high end bracket the measured number.
By their numbers in this assay, from the lowest: compounds 4, 2, 3 and 1 (each within the scatter of the next).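

In this assay, the one test of trifluoromethoxy at this position gives a 1.7-fold lower number from compound 3 to compound 4 (0.22 log units; within the scatter). Trifluoromethoxy in place of trifluoromethyl on an aromatic carbon, ortho to a large group, therefore brings in an oxygen and a hydrogen-bond acceptor with no readable change in the antiproliferative read-out, and compound 4 stands level with compound 3. The series now covers four aryl groups on sulfur, each compound within the scatter of the next by its number, and no measured property of these groups is available to set beside this result.

The compounds shown do not tell whether an amine or a carboxylic acid on this aromatic ring, in place of trifluoromethoxy, would carry the read-out beyond the scatter, nor whether trifluoromethoxy would behave the same way elsewhere on the ring. On these data alone, the rest of the shared core is the same in all four compounds, so the effect of a change there, such as a nitrile on the aromatic ring of the amide half, remains open.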